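Halogen swap on the arylidene ring across two cores

A few compounds are considered here, and "the series" means these few. Any claim that something is new, unique, unknown or untested is made for them only; others in the source may bear on it.

Compound 1 `O=C1/C(=C/c2ccccc2Cl)CCc2cc(O)ccc21` and compound 2 `O=C1/C(=C/c2ccccc2Br)CCc2cc(O)ccc21` share one core; compound 3 `O=C1/C(=C/c2ccc(Cl)cc2)CCc2ccc(O)cc21` and compound 4 `O=C1/C(=C/c2ccc(Br)cc2)CCc2ccc(O)cc21` share another. The difference between the two cores is not broken down here. In a functional assay on RAW264.7 cells (Mus musculus) for inhibition (a lower number here means a stronger inhibitor, a higher number a weaker inhibitor), compound 1 gives 1910 nM and compound 2 gives 1070 nM; that is a 1.8-fold lower number from compound 1 to compound 2 (0.25 log units; within the scatter), the change being (bromo in place of chloro on an aromatic carbon). In this assay compound 3 gives 1100 nM, which lies within the scatter of compound 2 and compound 1, so no order among the three is read from these numbers.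

Compound 4 carries the change (bromo in place of chloro on an aromatic carbon). It is the same kind of change as that from compound 1 to compound 2, but not the same: there the bromo enters ortho to a large group, here it enters para to a large group. The change occurs twice among the compounds shown, and only once with a measured result. Within the data shown here, the one measured instance stayed within the scatter, so the expectation for compound 4 rests on that single step and allows a wide range.

Among the measured compounds shown here, for compound 4 the estimate in this assay is 700 nM, with the range 350 nM to 1400 nM, because the only comparable step, a 1.8-fold lower number from compound 1 to compound 2 (0.25 log units; within the scatter), was small. The expected step of a 1.6-fold lower number from compound 3 to compound 4 (0.20 log units; within the scatter) is thus within the scatter.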

Compound 4, half-maximal inhibitory concentration: 800 nM
Estimate against measurement, compound 4: 1.1-fold (0.06 log units) below; measured number inside the range.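

In this assay, bromo in place of chloro, here para to a large group, gives a 1.4-fold lower number from compound 3 to compound 4 (0.14 log units; within the scatter). Set beside the earlier step on the other core, the same change gives a result that cannot be told apart from it: the same change on two cores in this assay, a 1.8-fold lower number (0.25 log units; within the scatter) from compound 1 to compound 2 and a 1.4-fold lower number (0.14 log units; within the scatter) from compound 3 to compound 4, 1.3-fold (0.11 log units) apart, within the scatter of two such steps. So these two pairs give no sign that the core alters what this change does, even though the halogen also sits at a different place on the ring in each pair; they do not, however, establish that bromo and chloro truly differ, as each step on its own lies within the scatter, and two pairs of compounds offer no firm ground for predicting the step on a further core.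

The compounds shown carry only chloro and bromo as the changing group, so it remains open how a smaller halogen such as fluoro, or a different kind of group such as a methoxy group, a nitrile or a carboxylic acid, would read in this assay at the same place. Also open is how each core and each halogen place contribute separately, as no pair shown isolates either one.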